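Acetyl removal on a pyridyl beta-lactam: expected cytotoxicity

The compounds below may be only part of what the source reports. "The series", "measured", "known", "first", "only" and "open" are said of these compounds alone.

Compound 1 `COc1ccc(C2C(O)C(=O)N2c2cc(OC)c(OC)c(OC)c2)cc1`: 33 nM
Compound 2 `COc1ccc(C2C(OC(C)=O)C(=O)N2c2cc(OC)c(OC)c(OC)c2)cn1`: > 1000 nM

Both measured compounds share a four-membered lactam core that carries a trimethoxyphenyl group on the nitrogen. In a functional assay on IMR-32 cells (Homo sapiens) for cytotoxicity (on this read-out higher numbers stand for weaker inhibition and lower numbers for stronger inhibition), compound 1, which bears a free hydroxy group on the ring, gives 33 nM. Compound 2 carries an acetoxy group in that place and a pyridine ring instead of the methoxyphenyl ring. In this assay compound 2 gives > 1000 nM, which is a limit of the assay rather than a number, so compound 2 stands at the weak end of what has been measured (the limit of > 1000 nM in this assay, at which 1 of the 2 values shown sits).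

Compound 3 `COc1ccc(C2C(O)C(=O)N2c2cc(OC)c(OC)c(OC)c2)cn1` has not yet been measured. It differs from compound 2 in one place: hydrogen in place of acetyl on an oxygen on a saturated carbon. The free hydroxy group of compound 1 goes with strong inhibition, while the acetoxy of compound 2 goes with a limit, so a step toward stronger inhibition is expected for compound 3, though its size cannot be read from a measured pair. The expected step of an at least 8.3-fold lower number from compound 2 to compound 3 (0.92 log units; beyond the scatter) points to lower numbers. Compound 3 is expected to give about 120 nM, within a range from 25 nM to 1000 nM.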

Compound 3, half-maximal inhibitory concentration: > 1000 nM
Compound 3 ended at the assay's limit (the forecaster's own chance of this, stated with the estimate: 20%); at least 8.3-fold (0.92 log units) between middle value and limit.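

The new pair isolates a single change, 6-methoxypyridin-3-yl in place of 4-methoxyphenyl on a saturated ring carbon, and in this assay it gives an at least 30-fold higher number from compound 1 to compound 3 (1.48 log units; beyond the scatter). With the hydroxy group kept the same, this shows that the ring on that carbon has a large effect on the read-out, something that could not be separated before, as compound 1 and compound 2 differ in two places at once. Compound 2 and compound 3 both rest at a limit of the assay rather than at a number, so the step from acetoxy to hydroxy cannot be read, and the free hydroxy group alone does not secure strong inhibition here: the limit of > 1000 nM in this assay, at which 2 of the 3 values shown sit.

The compounds shown leave open whether acetoxy in place of hydroxy changes the read-out when the 4-methoxyphenyl group is kept, which would give that step a readable size. They also leave open what other groups would give at the same places, such as an amine in place of the hydroxy group or an unsubstituted phenyl ring in place of the 4-methoxyphenyl group.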